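A dimethylimidazole swap on a rapidly cleared compound

The source may hold more compounds than are shown below. What is called first, only, known or untested is meant among the compounds shown, and "the series" means these compounds.

Within the data shown here, compound 1 `CC(C)C(Cc1ncc[nH]1)c1ccc(-c2ccc3cccc(F)c3c2)[nH]c1=O` is the only compound of its core measured here. In an ADME assay on microsomes from liver (Mus musculus) for metabolic stability (a higher number here means that the compound lasts longer, a lower number that the compound disappears faster), compound 1 gives < 0.0667 h, which is a limit of the assay and not a number, (the limit of < 0.0667 h in this assay, at which 1 of the 3 values shown sits). Compound 2 `CCn1ncc2c(F)cc(-c3ccc(C(CC)(CC)c4ncn(C)n4)c(=O)[nH]3)cc21` gives > 3 h in this assay, again a limit. Compound 3 `CCn1ncc2c(F)cc(-c3ccc(C(CC)(CC)c4nnc[nH]4)c(=O)[nH]3)cc21` gives > 3 h, also a limit. The step that the two limits leave unreadable from compound 2 to compound 3 therefore cannot be read, (the limit of > 3 h in this assay, at which 2 of the 3 values shown sit), and it concerns a different change on a different core. Compound 4 `Cc1nc(C(c2ccc(-c3ccc4cccc(F)c4c3)[nH]c2=O)C(C)C)[nH]c1C` differs from compound 1 by 4,5-dimethyl-1H-imidazol-2-yl in place of (1H-imidazol-2-yl)methyl on a saturated chain carbon bound to an aromatic carbon and a saturated chain carbon. Among the measured compounds shown here, no measured step bears on this change, so no move beyond the scatter is expected in either direction. Compound 4 is expected at 0.08 h, between 0.03 h and 0.3 h. The estimated step of an at least 1.1-fold higher number from compound 1 to compound 4 (0.07 log units; that floor lies within the scatter) is accordingly small.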

Compound 4, half-life: 0.0817 h
For compound 4 the middle estimate is 1.0-fold (0.01 log units) below the measured one, and the stated range covers the measured number.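

In this assay, placing 4,5-dimethyl-1H-imidazol-2-yl on this saturated chain carbon in place of (1H-imidazol-2-yl)methyl gives an at least 1.2-fold higher number from compound 1 to compound 4 (0.08 log units; that floor lies within the scatter). Compound 4 gives this core a number rather than a limit. The value of compound 1 is a limit of the assay, so only a floor for the step is known: the limit of < 0.0667 h in this assay, at which 1 of the 4 values shown sits.

The compounds shown do not separate the effect of the two methyl groups from that of removing the link between the ring and the chain carbon. A plain 1H-imidazol-2-yl at this place would bear on that question.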